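Working notes on a small antiproliferative series

This account rests on a few compounds, and the source may have more. Where it says the series, first, only, none or still open, it means among the compounds named here.

Going by the values given here, in a functional assay on HepG2 cells (Homo sapiens) for antiproliferative activity, read by MTT assay, with a stated time of 48 h (on this read-out higher numbers stand for weaker inhibition and lower numbers for stronger inhibition), compound 2 `CCOC(=O)CN(Cc1ccccc1)c1nc(Nc2ccc(Cl)cc2)ncc1[N+](=O)[O-]` gives 30900 nM, the only number so far. Compound 1 `CCOC(=O)CNc1nc(Nc2cccc(OC)c2)ncc1[N+](=O)[O-]` returns only a limit of the assay, > 100000 nM, and not a number. Compound 3 `COC(=O)CN(C)c1nc(NCc2ccccc2)ncc1[N+](=O)[O-]` likewise returns only a limit, > 100000 nM. Two of the three results therefore rest at the limit of > 100000 nM in this assay, at which 2 of the 3 values shown sit. Compound 4 `CCOC(=O)CN(Cc1ccccc1)c1nc(NCc2cccc(OC)c2)ncc1[N+](=O)[O-]` differs from compound 2 by one change: 3-methoxybenzyl in place of 4-chlorophenyl on a nitrogen on an aromatic ring. Compound 3, carrying a benzyl on a nitrogen on an aromatic ring, shows only the limit > 100000 nM. A step toward weaker inhibition in this assay is therefore expected, a 1.9-fold higher number from compound 2 to compound 4 (0.29 log units; within the scatter). Compound 4 is accordingly estimated at 60000 nM, within 20000 nM to 150000 nM, with a real chance that only a limit is reported.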

Compound 4, half-maximal inhibitory concentration: 33600 nM
Compound 4: the middle estimate sits 1.8-fold (0.25 log units) above what was measured; low and high end bracket the measured number.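

In this assay, 3-methoxybenzyl in place of 4-chlorophenyl on a nitrogen on an aromatic ring gives a 1.1-fold higher number from compound 2 to compound 4 (0.04 log units; within the scatter). The two groups cannot be told apart on this read-out, so the change of group at this nitrogen does not by itself carry compound 2 to a limit of the assay. Compound 4 adds a second number to a set otherwise resting at a limit: the limit of > 100000 nM in this assay, at which 2 of the 4 values shown sit.

As far as these compounds go, whether a basic amine or a longer alkyl chain on this nitrogen would move the number remains open. So does the effect of a carboxylic acid in place of the ethyl ester.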